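Phenylsulfonyl for Chlorobenzyl: Expected Potency of Compound 4

A few compounds are considered here, and "the series" means these few. Any claim that something is new, unique, unknown or untested is made for them only; others in the source may bear on it.

Compound 1 `C#CCNC1CCc2c(OCCCN3CCN(c4cccc5c4ccn5Cc4cccc(Cl)c4)CC3)cccc21` — in an assay on BTI cells for inhibition of Amine oxidase [flavin-containing] B (Homo sapiens), read by fluorescence, with stated times of 30 min and 1 h (on this read-out higher numbers stand for weaker inhibition and lower numbers for stronger inhibition), compound 1 gives only a limit, > 1000 nM.
Compound 2 `C#CCNC1CCc2c(OCCCCCN3CCN(c4cccc5c4ccn5Cc4cccc(Cl)c4)CC3)cccc21` — in this assay compound 2 gives 460 nM.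
Compound 3 `C#CCNC1CCc2c(OCCCCCCN3CCN(c4cccc5c4ccn5Cc4cccc(Cl)c4)CC3)cccc21` — in this assay compound 3 gives only a limit, > 1000 nM.

Within the data shown here, compound 2 therefore holds the only real number in this assay; the other two results sit at the limit of > 1000 nM in this assay, at which 2 of the 3 values shown sit. Compound 4 `C#CCNC1CCc2c(OCCCCCN3CCN(c4cccc5c4ccn5S(=O)(=O)c4ccccc4)CC3)cccc21` differs from compound 2 by phenylsulfonyl in place of 3-chlorobenzyl on an aromatic nitrogen. Among the measured compounds shown here, no measured pair shows this kind of change, so its direction stays open; a modest step in this assay in either direction, or none beyond the scatter, is expected. Compound 4 is estimated at 800 nM, with a range from 200 nM to 3000 nM. This corresponds to an expected step of a 1.7-fold higher number from compound 2 to compound 4 (0.24 log units; within the scatter).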

Compound 4, half-maximal inhibitory concentration: 163 nM
For compound 4 the middle estimate is 4.9-fold (0.69 log units) above the measured one, outside the stated range (below it).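

On the aromatic nitrogen, 3-chlorobenzyl is not required for inhibition: phenylsulfonyl in its place gives a 2.8-fold lower number from compound 2 to compound 4 (0.45 log units; beyond the scatter) in this assay. The earlier compounds shown here all carry 3-chlorobenzyl there and varied only in the chain, so they could not show this. Nothing measured here gives a cause for the step.

This one pair cannot separate the sulfonyl link from the loss of chlorine, so an unsubstituted benzyl or a chlorophenylsulfonyl group on that nitrogen would be needed to tell them apart. From the compounds shown here alone, whether phenylsulfonyl gives a similar step on the chains of compound 1 and compound 3 also stays open.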